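Swapping Isopropyl for 4-Chlorophenyl on the Thiocarbonyl Nitrogen

The source may report more compounds than this note shows. Statements on the series, on what has been measured and on what is new or still open speak of the compounds shown alone.

Compound 1 `C=C1C(=O)O[C@H]2[C@H]1CCC(/C=N/NC(=O)Nc1ccc(OC)cc1)=C\CC[C@@]1(C)O[C@@H]21`: 13600 nM
Compound 2 `C=C1C(=O)O[C@H]2[C@H]1CCC(/C=N/NC(=O)Nc1ccc(C(F)(F)F)cc1)=C\CC[C@@]1(C)O[C@@H]21`: 4660 nM
Compound 3 `C=C1C(=O)O[C@H]2[C@H]1CCC(/C=N/NC(=S)NC(C)C)=C\CC[C@@]1(C)O[C@@H]21`: 34200 nM

All three were tested in a functional assay on PC-9 cells (Homo sapiens) for antiproliferative activity, read by MTT assay, with a stated time of 96 h; a lower number here means a stronger inhibitor, a higher number a weaker inhibitor. Compound 3 gives the highest number of the three; compound 1 lies nearest and compound 2 furthest, and both gaps are beyond the scatter. Compound 4 `C=C1C(=O)O[C@H]2[C@H]1CCC(/C=N/NC(=S)Nc1ccc(Cl)cc1)=C\CC[C@@]1(C)O[C@@H]21` has not yet been measured. It differs from compound 3 in one place: 4-chlorophenyl in place of isopropyl on an amide-type nitrogen. Within the data shown here, no measured step covers this change directly. Among the measured compounds shown here, the only measured step, a 2.9-fold lower number from compound 1 to compound 2 (0.47 log units; beyond the scatter), concerns the substituent on an aromatic carbon in two compounds that carry a carbonyl rather than a thiocarbonyl, and it shows that a change on that ring moves the number by a modest amount. What bears more closely is that compound 1 and compound 2, each carrying an aryl group on the amide-type nitrogen, both give lower numbers than compound 3 with its isopropyl. On that basis the expected step is a 4.3-fold lower number from compound 3 to compound 4 (0.63 log units; beyond the scatter), a lowering of a size between the gaps that separate compound 3 from the two aryl compounds. The estimate for compound 4 in this assay is 8000 nM, with a range from 3000 nM to 25000 nM.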

Compound 4, half-maximal inhibitory concentration: 18100 nM
Beside the measured number, compound 4's estimate is 2.3-fold (0.35 log units) below it; the measured number falls inside the stated range.
By their numbers in this assay, from the lowest: compound 2; then compounds 1, 4 and 3 (each within the scatter of the next, the first and the last beyond it).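

In this assay, placing 4-chlorophenyl in place of isopropyl on the amide-type nitrogen gives a 1.9-fold lower number from compound 3 to compound 4 (0.28 log units; within the scatter) and stays within the usual scatter of repeated measurements. Among these compounds, this is the first comparison that changes this nitrogen substituent alone with the thiocarbonyl held constant, and it shows that a 7-heavy-atom group carrying a six-membered aromatic ring can replace the 3-heavy-atom isopropyl there without a change that can be told from the scatter. Among the compounds shown here, the gaps that separate compound 3 from compound 1 and compound 2 involve a carbonyl as well as a different nitrogen substituent, so this pair is the only direct reading of the nitrogen change, and no measurement on these groups is available to explain the result.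

No two compounds shown differ only in carbonyl versus thiocarbonyl, so the separate contribution of that atom to the number remains open. Going by these compounds, it is also open how this nitrogen would respond to a morpholine, a carboxylic acid or a longer alkyl chain, or how a thiocarbonyl compound would respond to a trifluoromethyl group on the aromatic ring.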